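Fluorine removal on the sulfonyl ring: notes toward compound 4

The source may report more compounds than this note shows. Statements on the series, on what has been measured and on what is new or still open speak of the compounds shown alone.

Three sulfonamides on a shared core have been measured in a functional assay on MCF7 cells (Homo sapiens) for cytotoxicity; on this read-out higher numbers stand for weaker inhibition of growth and lower numbers for stronger inhibition of growth. Compound 1 `COc1ccc(NS(=O)(=O)c2cc(F)c(F)c(F)c2F)cc1` gives 120 nM. Compound 3 `COc1ccc(NS(=O)(=O)c2cc(F)c(F)c(F)c2)cc1` gives 2000 nM, and compound 2 `COc1ccc(NS(=O)(=O)c2c(F)cc(F)c(F)c2F)cc1` gives 4500 nM, the highest number of the three. Compound 1 and compound 3 differ by hydrogen in place of fluoro on an aromatic carbon, a change that made a 17-fold higher number from compound 1 to compound 3 (1.22 log units; beyond the scatter). Compound 2 has the same atoms as compound 1, joined differently; the difference between the two cores is not broken down here, and the values alone show compound 2 standing far higher.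

Compound 4 `COc1ccc(NS(=O)(=O)c2c(F)cc(F)cc2F)cc1` has not yet been measured. It differs from compound 2 by hydrogen in place of fluoro on an aromatic carbon. This is the same kind of change as that from compound 1 to compound 3, not the same: there the place was ortho to a fluoro group, ortho to a large group and meta to a fluoro group, here it is ortho to two fluoro groups and meta to a large group. The step expected in this assay is a 3.3-fold higher number from compound 2 to compound 4 (0.52 log units; beyond the scatter). Going by the values given here, that expectation rests on a 17-fold higher number from compound 1 to compound 3 (1.22 log units; beyond the scatter), the one measured step of this kind, tempered by the changed surroundings of the place and by how high compound 2 already stands at 4500 nM. Compound 4 is estimated at 15000 nM, with a range from 4000 nM to 50000 nM.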

Compound 4, concentration for 50% growth inhibition: > 50000 nM
Compound 4: only a limit was reported (the forecaster's own chance of this, stated with the estimate: 20%); middle value at least 3.3-fold (0.52 log units) from the limit.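

In this assay, hydrogen in place of fluoro on an aromatic carbon gave a higher number on both cores, and the new step is an at least 11-fold higher number from compound 2 to compound 4 (1.04 log units; beyond the scatter). Set beside the earlier step, the change runs the same way at a place with different surroundings, though only the lower bound of the second step is known: the same change on two cores in this assay, a 17-fold higher number (1.22 log units; beyond the scatter) from compound 1 to compound 3 and an at least 11-fold higher number (1.04 log units; beyond the scatter) from compound 2 to compound 4; the limit leaves it open whether they differ. Compound 4 gives > 50000 nM, which is a limit and not a number, so the direction carries across these two cores but a size does not: the limit of > 50000 nM in this assay, at which 1 of the 4 values shown sits.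

As far as these compounds go, only fluoro and hydrogen are compared at the changed places, so it remains open whether a chloro group or an amine at such a place would follow the same direction. From the compounds shown here alone, it also remains open whether the step would hold if a carboxylic acid replaced the methoxy group of the shared core.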